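The source may hold more compounds than are shown below. What is called first, only, known or untested is meant among the compounds shown, and "the series" means these compounds.

In a functional assay on A549 cells (Homo sapiens) for cytotoxicity, read by MTT assay, with a stated time of 24 h (on this read-out higher numbers stand for weaker inhibition and lower numbers for stronger inhibition), compound 1 `O=c1nc2ccc(Br)cn2cc1Cc1ccc(Cl)cc1`, which carries a chloro group, gives 105000 nM. Compound 2 `O=c1nc2ccc(Br)cn2cc1Cc1ccccc1` has hydrogen in place of that chloro and shares the same core. Compound 2 reads > 1000000 nM, which is a limit of the assay and not a number. All that is known of compound 2, then, is this limit.

The next change leads to compound 3 `O=c1nc2ccccn2cc1Cc1ccccc1`: hydrogen in place of bromo on an aromatic carbon. This puts hydrogen in place of bromo on an aromatic carbon, on a six-membered aromatic ring with 1 nitrogen. Among the measured compounds shown here, one measured step bears on it, since it also swaps a halogen for hydrogen, although at another place in the molecule: an at least 9.5-fold higher number from compound 1 to compound 2 (0.97 log units; beyond the scatter). From the compounds shown here alone, that single step makes the number for compound 3 more likely to stay high than to fall, but it is a thin guide, and its true size is unknown. No clear step beyond the scatter is expected in this assay, and the assay may again report only a limit. The expected step is a number no higher from compound 2 to compound 3 (the limit leaves the size open). For compound 3 the estimated value is 1000000 nM, with an expected range of 250000 nM to 3000000 nM.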

Compound 3, half-maximal inhibitory concentration: 104000 nM
Compound 3: the middle estimate sits 9.6-fold (0.98 log units) above what was measured; the measured number lies below the stated range.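

In this assay, removing the bromo group from the six-membered aromatic ring with 1 nitrogen brings the read-out back from a limit to a measured number, giving an at least 9.6-fold lower number from compound 2 to compound 3 (0.98 log units; beyond the scatter). Swapping a halogen for hydrogen therefore has no single direction in these compounds: the earlier change at the chloro group gave an at least 9.5-fold higher number from compound 1 to compound 2 (0.97 log units; beyond the scatter), so the two steps run opposite ways and the place of the change matters, at least for this pair of steps. The new step has a lower bound but no known size, because compound 2 reads as a limit of the assay and not as a number: the limit of > 1000000 nM in this assay, at which 1 of the 3 values shown sits.

The compounds shown leave open how a group other than a halogen, such as an amine or a methoxy group, would read at the place the bromo group left, and whether a chloro group there would read like bromo. They also leave open whether putting the chloro group back onto compound 3 would push the number lower still, which would show how the two places act together.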